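The source may report more compounds than this note shows. Statements on the series, on what has been measured and on what is new or still open speak of the compounds shown alone.

Compound 1 `O=C(CCN1C(=O)CSc2ccccc21)N1CCN(c2ccc([N+](=O)[O-])cc2)CC1` in a functional assay (MiaPaCa cells, Homo sapiens) for inhibition, read by sulforhodamine B assay, with a stated time of 48 h (a lower number here means a stronger inhibitor of growth, a higher number a weaker inhibitor of growth), gives 68100 nM.
Compound 2 `O=C(CCN1C(=O)CSc2ccccc21)N1CCN(c2ccc(C(F)(F)F)cc2)CC1` in this assay gives only the assay limit > 100000 nM and no number.

Compound 2 thus stands at a limit only, and the step of an at least 1.4-fold higher number from compound 1 to compound 2 (0.16 log units; that floor lies within the scatter) is bounded by the limit of > 100000 nM in this assay, at which 1 of the 2 values shown sits. Compound 3 `CC(C)(C)OC(=O)N1CCN(C(=O)CCN2C(=O)CSc3ccccc32)CC1` differs from compound 2 by tert-butoxycarbonyl in place of 4-(trifluoromethyl)phenyl on an amine nitrogen in a ring. Among the measured compounds shown here, the single measured step, an at least 1.4-fold higher number from compound 1 to compound 2 (0.16 log units; that floor lies within the scatter), alters a substituent on the aromatic ring rather than the group on the ring nitrogen, so it bears only loosely on this change; no step beyond the scatter is expected in this assay in either direction. Compound 3 is estimated at 100000 nM (range 30000 nM to 300000 nM). The expected step is a number no higher from compound 2 to compound 3 (the limit leaves the size open).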

Compound 3, concentration for 50% growth inhibition: 51500 nM
Compound 3: middle estimate off by 1.9-fold (0.29 log units), on the high side; the range from low to high includes it.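

Tert-butoxycarbonyl, which has no ring, is not separated from 4-nitrophenyl on this amine nitrogen in a ring in this assay, with a 1.3-fold lower number from compound 1 to compound 3 (0.12 log units; within the scatter). Against 4-(trifluoromethyl)phenyl the same position gives an at least 1.9-fold lower number from compound 2 to compound 3 (0.28 log units; that floor lies within the scatter). Compound 2 gives only a limit, so the full size of that step cannot be read: the limit of > 100000 nM in this assay, at which 1 of the 3 values shown sits.

On these data alone, it remains open whether an acetyl or benzyl group on this nitrogen, or an amine on the aromatic ring of compound 1, would move the number beyond the scatter.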